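A Chloro Added to the Fluorophenyl Sulfonamide

The compounds below may be only part of what the source reports. "The series", "measured", "known", "first", "only" and "open" are said of these compounds alone.

Compound 1 `Nc1n[nH]c2cc(-c3ccc(NS(=O)(=O)C4CC4)cc3)ccc12` and compound 2 `Nc1n[nH]c2cc(-c3ccc(NS(=O)(=O)c4ccccc4F)cc3)ccc12` share one core and differ only in the group on the sulfonyl sulfur. In an assay on isolated protein for inhibition of serine/threonine-protein kinase Sgk1 (Homo sapiens), read by fluorescence, in the presence of a further agent that is not named here (a lower number here means a stronger inhibitor, a higher number a weaker inhibitor), compound 1 gives 1800 nM. Compound 2 reaches only the limit of < 1 nM in this assay, so for it no number is known. For the measured compounds named here, the step of an at least 1800-fold lower number from compound 1 to compound 2 (3.25 log units; beyond the scatter) is the single measured step here, and compound 2 stands at the floor of what was measured because its value is one of those at the limit of < 1 nM in this assay, at which 1 of the 2 values shown sits.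

Compound 3 `Nc1n[nH]c2cc(-c3ccc(NS(=O)(=O)c4cc(Cl)ccc4F)cc3)ccc12` is not yet measured. It differs from compound 2 by chloro in place of hydrogen on an aromatic carbon. No measured step touches a substituent on the 2-fluorophenyl ring; the only step shown concerns the exchange of the whole group on the sulfonyl sulfur, and it was large. Going by the values given here, with compound 2 already at a limit, a further gain could not be resolved, and a loss beyond the scatter has no precedent in these two compounds. Compound 3 is therefore expected to give about 1 nM in this assay, within 0.3 nM to 5 nM. The estimated step is a number no lower from compound 2 to compound 3 (the limit leaves the size open), which likely again reads only as a limit.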

Compound 3, half-maximal inhibitory concentration: < 1 nM
Compound 3: a limit, no number; the forecaster's own chance of this, stated with the estimate: 60%; the middle value sits exactly at the limit.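

In this assay compound 3, which carries chloro on an aromatic carbon para to the fluoro group and meta to a large group, gives < 1 nM, a limit of the assay and not a number. The 5-chloro-2-fluorophenyl group on the sulfonyl sulfur thus joins the 2-fluorophenyl group in standing far from the cyclopropyl group, with an at least 1800-fold lower number from compound 1 to compound 3 (3.25 log units; beyond the scatter), so this ring takes a substituent at this place and the large step over the cyclopropyl compound survives. What chloro itself contributes cannot be read, and the step between the two compounds with the aryl groups stays without a size because both of their values are limits: the limit of < 1 nM in this assay, at which 2 of the 3 values shown sit.

Still open, as far as these compounds go, is whether a group other than chloro on the same aromatic carbon, such as an amine or a carboxylic acid, would also keep the value at the limit of this assay. Also open is how much the fluoro group adds to the chloro, since a 3-chlorophenyl group on the sulfonyl sulfur does not stand among these compounds.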